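Methyl for fluoro at the cytotoxicity limit

This account rests on a few compounds, and the source may have more. Where it says the series, first, only, none or still open, it means among the compounds named here.

Measured in an ADME assay on HepG2 2.2.15 cells (Homo sapiens) for cytotoxicity, read by MTT assay, with a stated time of 8 days; a lower number here means that less compound is tolerated, a higher number that more compound is tolerated:
compound 1 `CCOc1ccc(-c2nn(Cc3ccc(C#N)cc3)c(=O)c3ccccc23)c(F)n1`: > 100000 nM, a limit
compound 2 `N#Cc1ccc(Cn2nc(-c3ccc(F)nc3F)c3ccccc3c2=O)cc1`: > 100000 nM, a limit

Compound 2 stands only as a limit, at > 100000 nM. It gives no number, and the same holds for compound 1, so the limit of > 100000 nM in this assay, at which 2 of the 2 values shown sit, is all that the series offers so far.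

The next compound, compound 3 `Cc1ccc(-c2nn(Cc3ccc(C#N)cc3)c(=O)c3ccccc23)c(F)n1`, carries methyl in place of fluoro on an aromatic carbon, next to the ring nitrogen, so that 2,6-difluoropyridin-3-yl becomes 2-fluoro-6-methylpyridin-3-yl: methyl in place of fluoro on an aromatic carbon.

For the measured compounds named here, one measured step bears on this carbon: a step that the two limits leave unreadable from compound 1 to compound 2, with fluoro in place of ethoxy. Its size cannot be read, so it supplies no magnitude to carry over. Even so, both groups measured at this carbon leave the compound at the limit. No step beyond the scatter is therefore expected in this assay, and a further limit reading is the likeliest result.

The expected change is a number no higher from compound 2 to compound 3 (the limit leaves the size open). Compound 3 is estimated at 100000 nM, with an expected range of 40000 nM to 150000 nM.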

Compound 3, half-maximal cytotoxic concentration: > 100000 nM
Compound 3: no number, only a limit (the forecaster's own chance of this, stated with the estimate: 80%); the middle value lies on the limit itself.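

In this assay compound 3 gives > 100000 nM as a limit and not a number. For the compounds shown here, no step among compound 1, compound 2 and compound 3 can be read, and the series rests on a single reading: the limit of > 100000 nM in this assay, at which 3 of the 3 values shown sit.

The compounds shown leave open how the three differ in cytotoxicity and whether any group at this carbon gives a measurable half-maximal cytotoxic concentration.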